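Methyl in place of chloro on the aryl ring

This account rests on a few compounds, and the source may have more. Where it says the series, first, only, none or still open, it means among the compounds named here.

Compound 2 `COc1cc(C(F)(F)F)cc(SC)c1C(=O)NC1(c2ccc(Cl)cc2)CCCN(C)C1` gives 28 nM in an assay on cells for inhibition of sodium- and chloride-dependent glycine transporter 1 (Homo sapiens); a lower number here means that less compound is needed, a higher number that more compound is needed for the effect. Within the data shown here, its only neighbour, compound 1 `COc1cc(C(F)(F)F)cc(SC)c1C(=O)NC1(c2ccccc2)CCCN(C)C1`, gives 24 nM in this assay; the two numbers lie within the scatter of each other, so compound 2 stands alongside compound 1 rather than apart from it. Among the measured compounds shown here, the single measured step, a 1.2-fold higher number from compound 1 to compound 2 (0.07 log units; within the scatter), shows that chloro in place of hydrogen at this position changes nothing beyond the scatter. Compound 3 `COc1cc(C(F)(F)F)cc(SC)c1C(=O)NC1(c2ccc(C)cc2)CCCN(C)C1` has not been measured; it differs from compound 2 by methyl in place of chloro on an aromatic carbon, the group sitting on an aromatic carbon of a six-membered aromatic ring of carbon only, para to a large group. For the measured compounds named here, no measured step exchanges chloro for methyl, so only the tolerance seen between compound 1 and compound 2 bears on it, and a step beyond the scatter is not expected. Compound 3 is therefore expected to give 28 nM in this assay. For compound 3 the estimate spans 12 nM to 65 nM. This estimate means a step of no change at the digits printed from compound 2 to compound 3 (within the scatter), expected to stay within the scatter.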

Compound 3, half-maximal effective concentration: 230 nM
Estimate against measurement, compound 3: 8.2-fold (0.91 log units) below; measured number outside the range, above it.
By their numbers in this assay, from the lowest: compounds 1 and 2 (each within the scatter of the next); then compound 3.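

At this place on the aromatic ring, para to a large group, the tolerance seen between hydrogen and chloro does not extend to methyl: in this assay methyl in place of chloro gives (an 8.2-fold higher number from compound 2 to compound 3 (0.91 log units; beyond the scatter)), and methyl in place of hydrogen gives (a 9.6-fold higher number from compound 1 to compound 3 (0.98 log units; beyond the scatter)). The position is therefore not indifferent to what it carries, since compounds 1 and 2 stay within the scatter of each other and only the methyl of compound 3 stands apart from both. Nothing at hand says why methyl parts from hydrogen and chloro here.

The compounds shown leave open whether this loss belongs to methyl alone or extends to other carbon groups, such as an ethyl or a trifluoromethyl. They also leave open how a methoxy, a nitrile or a bromo would fare at this place.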